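The source may report more compounds than this note shows. Statements on the series, on what has been measured and on what is new or still open speak of the compounds shown alone.

Values so far in a functional assay on HT-1080 cells (Homo sapiens) for cytotoxicity, read by MTT assay, with a stated time of 72 h (on this read-out higher numbers stand for weaker inhibition and lower numbers for stronger inhibition), are these:
- compound 1 `Cn1nc(-c2ccccc2)c2cc(C(=N)Nc3ccccc3)ncc21` gives 17400 nM
- compound 2 `COc1ccc(Cn2nc(-c3ccccc3)c3cc(C(=N)Nc4ccccc4)ncc32)cc1` gives 4700 nM
- compound 3 `COc1ccc(Cn2nc(-c3ccccc3)c3cc(C(=N)Nc4ccccc4)nc(NC4CCCCC4)c32)cc1` gives 3400 nM

Compound 2 (4700 nM) stands clearly below compound 1 (17400 nM), while compound 2 and compound 3 lie within the scatter of each other.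

Compound 4 `COc1ccc(Cn2ncc3cc(C(=N)Nc4ccccc4)ncc32)cc1` has not been measured yet. It is compound 2 with hydrogen in place of phenyl on an aromatic carbon. Going by the values given here, no measured step touches this phenyl, so the guidance is indirect. Two steps each added a group elsewhere. Putting 4-methoxyphenyl in place of hydrogen on a saturated chain carbon bound to an aromatic nitrogen gave a modest change (a 3.7-fold lower number from compound 1 to compound 2 (0.57 log units; beyond the scatter)). Putting cyclohexylamino in place of hydrogen on an aromatic carbon gave a change that cannot be told from noise (a 1.4-fold lower number from compound 2 to compound 3 (0.14 log units; within the scatter)). So adding a group lowered the number clearly in compound 2 but not in compound 3, and this is a weak precedent. Here a group leaves, so a modest rise seems more likely than a fall, no larger than the one modest step seen so far. The expected step in this assay is upward (a 2.0-fold higher number from compound 2 to compound 4 (0.31 log units; beyond the scatter)). Compound 4 is expected at 9500 nM (estimated range 3500 nM to 26000 nM).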

Compound 4, half-maximal inhibitory concentration: 25700 nM
Beside the measured number, compound 4's estimate is 2.7-fold (0.43 log units) below it; measured number inside the range.
By their numbers in this assay, from the lowest: compounds 3 and 2 (each within the scatter of the next); then compounds 1 and 4 (each within the scatter of the next).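

In this assay, going by these compounds alone, putting hydrogen in place of phenyl on the aromatic carbon of the five-membered ring gives the first direct reading of this position (a 5.5-fold higher number from compound 2 to compound 4 (0.74 log units; beyond the scatter)), and the step lies beyond the scatter. So the phenyl, six carbon atoms in one aromatic ring, counts for something in this cell assay: losing it clearly raises the number, whereas cyclohexylamino on another aromatic carbon made a change that cannot be told from noise (a 1.4-fold lower number from compound 2 to compound 3 (0.14 log units; within the scatter)), and this step is of the same modest class as the one for the 4-methoxyphenyl on the saturated chain carbon (a 3.7-fold lower number from compound 1 to compound 2 (0.57 log units; beyond the scatter)). Nothing measured here explains why the phenyl matters, so the reason for this step remains unknown.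

With only phenyl and hydrogen shown at this carbon, it remains open whether a small group such as methyl would do as well as phenyl, or whether a ring carrying something more, such as 4-fluorophenyl or a pyridine ring, would lower the number further. From the compounds shown here alone, it is also open whether cyclohexylamino would have the same small effect on compound 4, which lacks the phenyl.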